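A few compounds are considered here, and "the series" means these few. Any claim that something is new, unique, unknown or untested is made for them only; others in the source may bear on it.

Measured so far in a functional assay on CHO cells for positive allosteric modulation of muscarinic acetylcholine receptor M5 (Homo sapiens), read by FLIPR and calcium flux, with a stated time of 1 h; a lower number here means that less compound is needed, a higher number that more compound is needed for the effect:
- compound 1, `O=C1C(=O)N(Cc2ccc(-c3ccccc3)cc2F)c2ccc(OC(F)(F)F)cc21`: 5900 nM
- compound 2, `O=C1C(=O)N(Cc2ccc(-c3ccncc3)nc2)c2ccc(OC(F)(F)F)cc21`: 4400 nM
- compound 3, `O=C1C(=O)N(Cc2ccc(Oc3ccccn3)cc2)c2ccc(OC(F)(F)F)cc21`: 3200 nM

Compound 3 has the lowest of the three numbers in this assay, but its gap to compound 2 and its gap to compound 1 are both within the usual scatter of repeated measurements, so the three compounds cannot be told apart on these values. Compound 4, `O=C1C(=O)N(Cc2ccc(-c3ccncc3)cc2)c2ccc(OC(F)(F)F)cc21`, has not yet been measured in this assay. It differs from compound 3 in one place: pyridin-4-yl in place of (pyridin-2-yl)oxy on an aromatic carbon. Within the data shown here, no step between two measured compounds isolates this change, so there is no measured step to lean on. The values of compound 1 and compound 2, which carry a directly attached aryl group rather than an aryloxy linker, sit within the scatter of compound 3, so compound 4 is expected to show no step beyond the scatter, a 1.3-fold higher number from compound 3 to compound 4 (0.12 log units; within the scatter). Compound 4 is therefore estimated at 4200 nM, with a range from 1500 nM to 12000 nM.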

Compound 4, half-maximal effective concentration: 2800 nM
Estimate against measurement, compound 4: 1.5-fold (0.18 log units) above; the range from low to high includes it.
By their numbers in this assay, from the lowest: compounds 4, 3, 2 and 1 (each within the scatter of the next, the first and the last beyond it).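

In this assay, replacing (pyridin-2-yl)oxy with pyridin-4-yl on an aromatic carbon, para to a large group, gives a 1.1-fold lower number from compound 3 to compound 4 (0.06 log units; within the scatter). Among these compounds, this is the first measured step to isolate a change at this position, and it shows that the oxygen linker can give way to a directly attached ring with no change that can be told from the scatter. The step changes the linker and the place of the ring nitrogen together, and no information is available to explain the result or to separate these two parts.

The compounds shown all carry an aromatic ring at this position, and it remains open how the number would respond to an amine such as piperidin-1-yl or to a carboxylic acid there. Also open, as far as these compounds go, is whether a group other than trifluoromethoxy on the shared core would shift the number.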